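Methyl to allyl on the core of compound 1

The source may hold more compounds than are shown below. What is called first, only, known or untested is meant among the compounds shown, and "the series" means these compounds.

- compound 1 (`C[C@@H]1[C@H]2CC(=O)[C@H](C)[C@H]2C[C@H]1O[Si](c1ccccc1)(c1ccccc1)C(C)(C)C`), 15200 nM
- compound 2 (`C=CCC[C@H]1CC(=O)[C@@H]2C=CC(=O)[C@H]12`), 16300 nM
- compound 3 (`O=C1C=C[C@H]2C(=O)C=C[C@@H]12`), 6000 nM

In a functional assay on KB 3-1 cells (Homo sapiens) for antiproliferative activity, read by MTT assay (a higher number here means a weaker inhibitor, a lower number a stronger inhibitor), compound 1 (15200 nM) holds the second highest of the three numbers. It lies within the scatter of compound 2 and beyond the scatter above compound 3.

The next compound is compound 4 (`C=CC[C@H]1C(=O)C[C@@H]2[C@@H](C)[C@H](O[Si](c3ccccc3)(c3ccccc3)C(C)(C)C)C[C@@H]21`), which has vinyl in place of hydrogen on a saturated chain carbon bound to a saturated ring carbon. Cut one bond further out, the same difference reads methyl to allyl.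

Among the measured compounds shown here, no pair of measured compounds differs in one place, so the series gives no direct measure of this change. Compound 2 (16300 nM) also carries an unsaturated chain, but on a different core, and this is only a loose guide. No step beyond the scatter is expected in this assay, and no firm direction can be claimed. The expected step, a 1.2-fold lower number from compound 1 to compound 4 (0.07 log units; within the scatter), is an estimate within the scatter. For compound 4 the estimated value is 13000 nM, with an expected range from 6000 nM to 30000 nM.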

Compound 4, half-maximal inhibitory concentration: 6900 nM
For compound 4 the middle estimate is 1.9-fold (0.28 log units) above the measured one; the range from low to high includes it.
By their numbers in this assay, from the lowest: compounds 3 and 4 (each within the scatter of the next); then compounds 1 and 2 (each within the scatter of the next).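

In this assay, among the compounds shown here, the exchange of methyl for allyl on the core of compound 1 gives the first direct reading of this position, and that reading is a 2.2-fold lower number from compound 1 to compound 4 (0.34 log units; beyond the scatter) on a single change. The earlier compounds shown here offered only a loose guide from a different core, whereas this pair shows that vinyl in place of hydrogen on a saturated chain carbon bound to a saturated ring carbon can move the number past the scatter, towards a stronger inhibitor, though only modestly. No measured evidence here bears on what lies behind this step.

On these data alone, whether the step belongs to the double bond or simply to the added carbons stays open, and a saturated propyl chain in place of allyl would separate the two. Also open, as far as these compounds go, is how a longer chain, an amine or a carboxylic acid in that place would read on the same core.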